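Removing the acetyl group from compound 3

The compounds below may be only part of what the source reports. "The series", "measured", "known", "first", "only" and "open" are said of these compounds alone.

In a functional assay (trachea) with Cavia porcellus as the target (a higher number here means that more compound is needed for the effect, a lower number that less compound is needed), compound 3 `CCCn1c(=O)n(CC(C)=O)c(=O)c2[nH]cnc21` gives 14900 nM and compound 2 `CCCn1c(=O)n(CCCN(C)C)c(=O)c2[nH]cnc21` gives 20500 nM. These two values sit together at the high end of the three measured, as a 1.4-fold lower number from compound 2 to compound 3 (0.14 log units; within the scatter) shows. Compound 1 `C=CCCn1c(=O)c2[nH]cnc2n(CCC)c1=O` stands well apart at 200 nM, and the gap is given by a 75-fold higher number from compound 1 to compound 3 (1.87 log units; beyond the scatter).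

Compound 4 `CCCn1c(=O)n(C)c(=O)c2[nH]cnc21` follows from compound 3 by hydrogen in place of acetyl on a saturated chain carbon bound to an aromatic nitrogen. The same difference, cut one bond further out, reads 2-oxopropyl to methyl.

For the measured compounds named here, no measured step makes this exact change. Two large steps bear on it at the same part of the structure: a 75-fold higher number from compound 1 to compound 3 (1.87 log units; beyond the scatter) and a 100-fold higher number from compound 1 to compound 2 (2.01 log units; beyond the scatter). They show that this substituent can move the number strongly. The near-identical values of compound 2 and compound 3 show that two quite different chain ends can land at the same level. Methyl carries neither of those ends, nor the allyl of compound 1, so a modest move toward lower numbers is expected, well short of the full gap.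

The expected change is a 2.5-fold lower number from compound 3 to compound 4 (0.40 log units; beyond the scatter). For compound 4 the estimated value is 6000 nM, with an expected range from 1800 nM to 20000 nM.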

Compound 4, half-maximal effective concentration: 1600 nM
Compound 4: the middle estimate sits 3.8-fold (0.57 log units) above what was measured; the measured number lies below the stated range.
By their numbers in this assay, from the lowest: compound 1; then compound 4; then compounds 3 and 2 (each within the scatter of the next).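

In this assay, the small methyl end does not share the high level of the two larger substituents: hydrogen in place of acetyl gives a 9.3-fold lower number from compound 3 to compound 4 (0.97 log units; beyond the scatter), and hydrogen in place of 2-(dimethylamino)ethyl gives a 13-fold lower number from compound 2 to compound 4 (1.11 log units; beyond the scatter). The level common to compound 2 and compound 3 therefore belongs to those two substituents and is not a general level for this place on the shared core. Methyl does not match the allyl end, however, as hydrogen in place of allyl gives an 8.0-fold higher number from compound 1 to compound 4 (0.90 log units; beyond the scatter), so size alone does not order the set: compound 1 carries a larger substituent than compound 4 yet has the lower number, while compound 2 and compound 3 carry larger substituents and have the higher numbers.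

Going by these compounds, it remains open whether a saturated butyl chain at this place would stay near compound 1 or near compound 4, and whether a carboxylic acid or a hydroxyl at the chain end would give the high level of compound 2 and compound 3. Nothing among the data shown explains why these substituents differ as they do.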